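The compounds below may be only part of what the source reports. "The series", "measured", "known", "first", "only" and "open" are said of these compounds alone.

In a functional assay on HFF cells (Homo sapiens) for cytotoxicity (on this read-out lower numbers stand for stronger inhibition and higher numbers for weaker inhibition), compound 1 (`CCOC[C@H]1O[C@@H](n2c(Cl)nc3cc(Cl)c(Cl)cc32)[C@H](OC(C)=O)[C@@H]1OC(C)=O`) gives 33000 nM as its reading, and compound 2 (`COC[C@H]1OC(n2c(Cl)nc3cc(Cl)c(Cl)cc32)[C@H](O)[C@@H]1O`) gives 32000 nM on the same read-out. These two values lie within the scatter of each other, so compound 2 cannot be ranked against compound 1. The next compound is compound 3 (`O[C@@H]1[C@@H](CI)OC(n2c(Cl)nc3cc(Cl)c(Cl)cc32)[C@@H]1O`), which carries iodomethyl where compound 2 carries methoxymethyl. This is iodo in place of methoxy on a saturated chain carbon bound to a saturated ring carbon. Among the measured compounds shown here, the series holds no measured step between compounds that differ in one place, so nothing calibrates this change directly. With so little to go on, the expectation in this assay is a modest move toward a lower number, perhaps not far beyond the scatter. The expected size of the change is a 1.6-fold lower number from compound 2 to compound 3 (0.20 log units; within the scatter) on this estimate. For compound 3 the estimated value is 20000 nM with an expected range of 7000 nM to 50000 nM across repeated measurements.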

Compound 3, half-maximal inhibitory concentration: 32000 nM
Beside the measured number, compound 3's estimate is 1.6-fold (0.20 log units) below it; the range from low to high includes it.
By their numbers in this assay, from the lowest: compounds 2, 3 and 1 (each within the scatter of the next).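

In this assay, among the compounds shown here, iodo in place of methoxy on a saturated chain carbon bound to a saturated ring carbon gives no change at the digits printed from compound 2 to compound 3 (within the scatter), the first step that can be read at a single place. On this read-out, methoxymethyl and iodomethyl therefore cannot be told apart at this position, even though the change takes out one hydrogen-bond acceptor and replaces two heavy atoms with one. No supporting measurement bears on this result, so it stands as a plain observation on this one pair.

Open, as far as these compounds go, is whether the reading at this position would hold for a group of a different kind, such as aminomethyl or a carboxylic acid in place of methoxymethyl. For the compounds shown here, one pair also leaves open whether iodo in place of methoxy would read the same way on the core of compound 1, which differs from compound 2 in more than one place and so gives no step for this change.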